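The compounds below may be only part of what the source reports. "The series", "measured", "known", "first", "only" and "open" are said of these compounds alone.

Measured compounds:
compound 1, `OCc1cc(O)c(O)c(Br)c1`, 51500 nM
compound 2, `O=Cc1cc(O)c(O)c(Br)c1Br`, 30900 nM
compound 3, `CCOCc1cc(O)c(O)c(Br)c1`, 35100 nM

In a functional assay on DLD-1 cells (Homo sapiens) for cytotoxicity, read by MTT assay, with a stated time of 96 h (a higher number here means a weaker inhibitor, a lower number a stronger inhibitor), compound 1 gives 51500 nM, compound 2 gives 30900 nM, and compound 3 gives 35100 nM. Among these three numbers compound 3 sits nearest to compound 2 and farthest from compound 1, yet both gaps are within the usual scatter, so the three compounds cannot be told apart on this evidence. Going by the values given here, the one step that joins two compounds differing in a single place is a 1.5-fold lower number from compound 1 to compound 3 (0.17 log units; within the scatter), which also lies within the scatter.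

Compound 4, `CCOCc1cc(O)c(O)c(Br)c1Br`, differs from compound 3 in one place: bromo in place of hydrogen on an aromatic carbon. Among the compounds with values here, no measured pair shows this change alone. Compound 2 carries the same pattern of two bromo groups, but it differs from compound 3 in a second place as well, so its value only hints that such a pattern is compatible with a number of roughly this size. Within the data shown here, the one measured step was within the scatter, and nothing here points to a large shift in either direction. The expectation is therefore that compound 4 gives a number close to that of compound 3, with the step of a 1.3-fold lower number from compound 3 to compound 4 (0.10 log units; within the scatter) expected to stay within the scatter. Compound 4 is estimated at 28000 nM, with a likely range from 12000 nM to 70000 nM.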

Compound 4, half-maximal inhibitory concentration: 13500 nM
The estimate for compound 4 lay 2.1-fold (0.32 log units) above the measured number; the range from low to high includes it.
By their numbers in this assay, from the lowest: compound 4; then compounds 2, 3 and 1 (each within the scatter of the next).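

In this assay, going by these compounds alone, a bromo group on the aromatic carbon ortho to the ethoxymethyl group and para to a hydroxy group gives a 2.6-fold lower number from compound 3 to compound 4 (0.41 log units; beyond the scatter), the first single change here that lies beyond the scatter, so this position can affect the number. With both bromo groups present, ethoxymethyl in place of formyl on an aromatic carbon gives a 2.3-fold lower number from compound 2 to compound 4 (0.36 log units; beyond the scatter), so the choice of group at that carbon also shows a difference in this pair. Nothing available bears on why either step lowers the number.

As far as these compounds go, it remains open whether the lower number belongs to bromo specifically or would also come with chloro or a methyl group on the same carbon. From the compounds shown here alone, it is also open how the number would respond with both bromo groups kept and a longer chain, an amine or a carboxylic acid in place of ethoxymethyl, which would show whether the step seen from formyl to ethoxymethyl extends to other groups.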